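Dropping a Ring from a Serotonin Receptor Ligand

The source may report more compounds than this note shows. Statements on the series, on what has been measured and on what is new or still open speak of the compounds shown alone.

Three compounds share a core with a saccharin-like head, a carbon chain and a piperazine ring bearing an aromatic group. Compound 1 `O=C1c2ccccc2S(=O)(=O)N1CCCCN1CCN(c2cccc(Cl)c2Cl)CC1` gives 372 nM in an assay on HEK293 cells for displacement of a labelled ligand from 5-hydroxytryptamine receptor 7 (Homo sapiens); a higher number here means a weaker inhibitor, a lower number a stronger inhibitor. Compound 2 `O=C1c2ccccc2S(=O)(=O)N1CCCCCN1CCN(c2cccc3ccccc23)CC1` gives 36 nM in this assay. Compound 3 `O=C1c2ccccc2S(=O)(=O)N1CCCCCCN1CCN(c2ccc(Cl)cc2)CC1` gives 487 nM. Compound 2 thus stands lowest of the three numbers, with compound 1 and compound 3 both well beyond the scatter above it.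

The next compound, compound 4 `O=C1c2ccccc2S(=O)(=O)N1CCCCCN1CCN(c2ccccc2)CC1`, keeps the core and the chain of compound 2 and changes only the aromatic group on the piperazine: phenyl in place of naphthalen-1-yl on an amine nitrogen in a ring

Among the compounds with values here, no pair among the measured compounds differs in a single place, so no measured step guides this change directly. Within the data shown here, the only compound carrying a naphthalen-1-yl group, compound 2, gives the lowest number seen, while both phenyl-bearing compounds give much higher numbers, though they also differ in chain length and ring substituents. A step toward a weaker inhibitor is therefore expected a 5.6-fold higher number from compound 2 to compound 4 (0.74 log units; beyond the scatter). Compound 4 is estimated at 200 nM, with a likely range from 60 nM to 700 nM.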

Compound 4, inhibition constant: 148 nM
Compound 4: middle estimate off by 1.4-fold (0.13 log units), on the high side; the range from low to high includes it.
By their numbers in this assay, from the lowest: compound 2; then compound 4; then compounds 1 and 3 (each within the scatter of the next).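

With the core and the chain held fixed, replacing naphthalen-1-yl with phenyl on the piperazine nitrogen leads to a 4.1-fold higher number from compound 2 to compound 4 (0.61 log units; beyond the scatter) in this assay. Within the data shown here, this is the first comparison here that isolates the aromatic group, separating its contribution from differences in chain length and ring substituents; the loss of one aromatic ring makes the compound a weaker inhibitor, though compound 4 still gives 148 nM. No measurement shown explains why the two aromatic groups give different numbers.

Going by these compounds, whether a methoxy group on the phenyl ring could bring the number back towards that of compound 2 remains open. Also open, on these data alone, is whether the same swap would give a step of similar size on a shorter or longer chain.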